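This account rests on a few compounds, and the source may have more. Where it says the series, first, only, none or still open, it means among the compounds named here.

In a functional assay on A549 cells (Homo sapiens) for inhibition, read by CCK-8 assay, with a stated time of 72 h, tested at 1 uM (on this read-out higher numbers stand for more inhibition of growth at the one concentration tested and lower numbers for less inhibition of growth), compound 1 `CN(C)C(=O)c1cc2cnc(Nc3ccc(NC(=O)C4(C(=O)Nc5ccc(F)cc5)CC4)cc3)nc2n1C1CCCC1` gives 86.6%, compound 2 `CN(C)C(=O)c1cc2cnc(Nc3ccc(NC(=O)C4(C(=O)Nc5ccc(Cl)cc5)CC4)cc3)nc2n1C1CCCC1` gives 24.7% and compound 3 `CN(C)C(=O)c1cc2cnc(Nc3ccc(NC(=O)C4(C(=O)Nc5cccc(F)c5)CC4)cc3)nc2n1C1CCCC1` gives 33.2%. Compound 3 therefore sits far from the top number, a number 53.4 percentage points lower from compound 1 to compound 3 (beyond the scatter), and close to the other one, a number 8.5 percentage points higher from compound 2 to compound 3 (within the scatter). Compound 4 `CN(C)C(=O)c1cc2cnc(Nc3ccc(NC(=O)C4(C(=O)Nc5ccccc5F)CC4)cc3)nc2n1C1CCCC1` changes it by 2-fluorophenyl in place of 3-fluorophenyl on an amide-type nitrogen. Within the data shown here, the nearest precedent is the exchange of 4-fluorophenyl for 3-fluorophenyl, a number 53.4 percentage points lower from compound 1 to compound 3 (beyond the scatter), which was large, so a sizeable shift cannot be excluded. Among the measured compounds shown here, no measured compound carries 2-fluorophenyl, however, so the direction stays open and only a modest rise is assumed. The expected change is a number 6.8 percentage points higher from compound 3 to compound 4 (within the scatter). For compound 4 the estimated value is 40%, with an expected range of 15% to 72%.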

Compound 4, percent growth inhibition at one concentration: 79.1%
Beside the measured number, compound 4's estimate is 39.1 percentage points below it; measured number above the stated range.
By their numbers in this assay, from the lowest: compounds 2 and 3 (each within the scatter of the next); then compounds 4 and 1 (each within the scatter of the next).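

On this assay the place of the fluorine on the phenyl group turns out to matter in a way that does not simply follow from leaving the 4-fluorophenyl group: 2-fluorophenyl gives a number 45.9 percentage points higher from compound 3 to compound 4 (beyond the scatter) and a number 54.4 percentage points higher from compound 2 to compound 4 (beyond the scatter), yet a number 7.5 percentage points lower from compound 1 to compound 4 (within the scatter). Among the three compounds with one fluorine or chlorine on the ring that differ from compound 1 here, 3-fluorophenyl and 4-chlorophenyl go against the high numbers of the other two. Nothing available explains this difference. Going by these compounds, whether 2-chlorophenyl or 3-chlorophenyl behaves like its fluorine counterpart stays open. So does what unsubstituted phenyl or 2-methoxyphenyl would give on this amide-type nitrogen.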